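The source may report more compounds than this note shows. Statements on the series, on what has been measured and on what is new or still open speak of the compounds shown alone.

Measured so far in an ADME assay on Vero cells (Chlorocebus sabaeus) for cytotoxicity, read by resazurin assay, with a stated time of 72 h; a higher number here means a weaker inhibitor, a lower number a stronger inhibitor:

- compound 1 `O=C(CCN1CCN(c2ccc(F)cc2)CC1)c1ccccc1`: 13400 nM
- compound 2 `O=C(CCN1CCN(c2ccc(C(F)(F)F)cc2)CC1)c1ccccc1`: 15700 nM
- compound 3 `COc1ccc(C(=O)CCN2CCN(c3ccc([N+](=O)[O-])cc3)CC2)cc1OC`: 105000 nM

The account follows compound 2, which gives 15700 nM and stands within the scatter of compound 1. Compound 3 is the clear outlier of the three, with a higher number than either of the others. The next structure is compound 4 `O=C(CCN1CCN(c2ccc(C(F)(F)F)cc2)CC1)c1ccc(F)c(Cl)c1`, which keeps everything in compound 2 except one group: 3-chloro-4-fluorophenyl in place of phenyl on a carbonyl carbon. In words, 3-chloro-4-fluorophenyl replaces phenyl on a carbonyl carbon.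

For the measured compounds named here, only one measured step links two compounds that differ in a single place: a 1.2-fold higher number from compound 1 to compound 2 (0.07 log units; within the scatter). That step puts trifluoromethyl in place of fluoro on an aromatic carbon, so it concerns a different group and bears on this change only indirectly. Going by the values given here, no measured step changes the group on the carbonyl carbon alone. Compound 3 differs from compound 2 in more than one place, so its number cannot be assigned to any single group. As far as these compounds go, on this thin evidence, no step beyond the scatter is expected in this assay, and the direction stays open. The estimated change is a 1.1-fold lower number from compound 2 to compound 4 (0.05 log units; within the scatter). For compound 4 the expected value is 14000 nM, with an estimated range of 6000 nM to 35000 nM.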

Compound 4, half-maximal inhibitory concentration: 74500 nM
The estimate for compound 4 lay 5.3-fold (0.73 log units) below the measured number, outside the stated range (above it).
By their numbers in this assay, from the lowest: compounds 1 and 2 (each within the scatter of the next); then compounds 4 and 3 (each within the scatter of the next).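

The group on the carbonyl carbon proves to be a place where the number in this assay can move: putting 3-chloro-4-fluorophenyl in place of phenyl gives a 4.7-fold higher number from compound 2 to compound 4 (0.68 log units; beyond the scatter) and is the first single-place step shown that lies beyond the scatter. For the compounds shown here, the only earlier step of this kind, a 1.2-fold higher number from compound 1 to compound 2 (0.07 log units; within the scatter), changed a group on an aromatic carbon elsewhere in the structure and stayed within the scatter, so the earlier compounds gave no sign that a single change could shift this read-out. Nothing measured here accounts for the shift, and the result stands as an observation without an explanation.

Chlorine and fluorine enter together in this change, so the compounds shown cannot tell whether one of them alone would produce the step or whether both are needed. As far as these compounds go, it also remains open how this position would respond to a different kind of group on the ring, such as an amine or a carboxylic acid, and whether the step would be of similar size with fluoro in place of trifluoromethyl on the other aromatic ring.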